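Varying the Group on the Ring Amine Nitrogen

A few compounds are considered here, and "the series" means these few. Any claim that something is new, unique, unknown or untested is made for them only; others in the source may bear on it.

Of the compounds shown here, three sharing one core have been measured in a functional assay on MCF7 cells (Homo sapiens) for cytotoxicity, read by MTT assay, with a stated time of 24 h, tested at 1.6 ug/mL; on this read-out lower numbers stand for a weaker effect and higher numbers for a stronger effect at the one concentration tested. Compound 1 `Cn1c(-c2ccc(NC(=O)CSc3nc4cc(Cl)ccc4o3)cc2)nc(-c2ccccc2)c1-c1ccccc1` gives 2.5%. Compound 2 `CCN1CCN(CC(=O)Nc2ccc(-c3nc(-c4ccccc4)c(-c4ccccc4)n3C)cc2)CC1` gives 14.6%. Compound 3 `Cn1c(-c2ccc(NC(=O)CN3CCN(c4ccccc4)CC3)cc2)nc(-c2ccccc2)c1-c1ccccc1` gives 21.3%, the highest of the three numbers; the nearest is compound 2, within the scatter, and the furthest is compound 1, beyond the scatter. Replacing the group on the saturated chain carbon bound to the carbonyl carbon gave a number 12.1 percentage points higher from compound 1 to compound 2 (beyond the scatter) and a number 18.8 percentage points higher from compound 1 to compound 3 (beyond the scatter), both modest steps. Replacing the group on the amine nitrogen in the ring gave a number 6.7 percentage points higher from compound 2 to compound 3 (within the scatter), which is within the scatter.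

Compound 4 `Cc1ccc(CN2CCN(CC(=O)Nc3ccc(-c4nc(-c5ccccc5)c(-c5ccccc5)n4C)cc3)CC2)cc1` differs from compound 3 only on the amine nitrogen in the ring: 4-methylbenzyl in place of phenyl on an amine nitrogen in a ring. Among the measured compounds shown here, the one measured step at this place, a number 6.7 percentage points higher from compound 2 to compound 3 (within the scatter), stayed within the scatter, and that is the only guidance for a change there; the two larger steps concern a different part of the molecule. Accordingly, a step of a number 0.3 percentage points lower from compound 3 to compound 4 (within the scatter) is expected, that is, no change beyond the scatter. Compound 4 is therefore estimated at 21% in this assay, with a likely range from 9% to 33%.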

Compound 4, a percentage reported as activity, at one concentration (the size of the read-out at that concentration, not a potency): 19.3%
The estimate for compound 4 lay 1.7 percentage points above the measured number; the range from low to high includes it.
By their numbers in this assay, from the lowest: compound 1; then compounds 2, 4 and 3 (each within the scatter of the next).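

In this assay, 4-methylbenzyl, with 8 heavy atoms, in place of phenyl, with 6, gives a number 2 percentage points lower from compound 3 to compound 4 (within the scatter), so this larger group on the amine nitrogen in the ring cannot be told apart from phenyl. Compared with the ethyl group, read here as 4-methylphenyl in place of methyl on the saturated chain carbon bound to that nitrogen, the result is a number 4.7 percentage points higher from compound 2 to compound 4 (within the scatter), so compounds 2, 3 and 4 all read alike and none goes against that for now. No measurement here explains this insensitivity to the change of group on this nitrogen.

Going by these compounds, all three groups on this nitrogen are built only from carbon and hydrogen, so it remains open whether a hydroxyethyl chain or a carboxylic acid there would move the number beyond the usual scatter. A plain benzyl group would be needed to judge the methyl on the ring by itself, and because each number comes from one concentration, the potency of these compounds also remains open.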